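Working notes: from compound 2 to compound 3

The source may report more compounds than this note shows. Statements on the series, on what has been measured and on what is new or still open speak of the compounds shown alone.

In a functional assay on BXPC-3 cells (Homo sapiens) for cytotoxicity (a higher number here means a weaker inhibitor, a lower number a stronger inhibitor), compound 1 (`C[C@@H]1O[C@@H](n2c3ccccc3c3c4c(c5c6ccccc6ccc5c32)C(=O)NC4=O)[C@H](O)[C@H](O)[C@H]1O`) gives 7300 nM and compound 2 (`O=C1NC(=O)c2c1c1c3ccccc3ccc1c1c2c2ccccc2n1[C@H]1OC[C@@H](O)[C@@H](O)[C@H]1O`) gives 6600 nM. These two values lie within the scatter of each other, so compound 2 cannot be separated from compound 1 on the numbers available.

Compound 3 (`O=C1NC(=O)c2c1c1c3ccccc3ccc1c1c2c2ccccc2n1[C@@H]1O[C@H](CO)[C@@H](O)[C@H](O)[C@H]1O`) keeps the core of compound 2 and changes the group on an aromatic nitrogen of a five-membered aromatic ring with 1 nitrogen: a group of 11 heavy atoms (6 carbon, 5 oxygen; one six-membered non-aromatic ring with 1 hetero atom) in place of a group of 9 heavy atoms (5 carbon, 4 oxygen; one six-membered non-aromatic ring with 1 hetero atom), on an aromatic nitrogen. The entering group is 3,4,5-trihydroxy-6-(hydroxymethyl)oxan-2-yl.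

Among the measured compounds shown here, only one measured step bears on this change: a 1.1-fold lower number from compound 1 to compound 2 (0.04 log units; within the scatter). It is also an exchange of groups on an aromatic nitrogen, and it stays within the scatter. For the measured compounds named here, this is thin evidence, since no measured compound carries the entering group. No step beyond the scatter is therefore expected in this assay, and no direction is assigned. The expected step is a 1.0-fold lower number from compound 2 to compound 3 (0.01 log units; within the scatter). Compound 3 is estimated at 6500 nM, with an expected range of 2500 nM to 17000 nM.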

Compound 3, half-maximal inhibitory concentration: 5400 nM
Compound 3: the middle estimate sits 1.2-fold (0.08 log units) above what was measured; the range from low to high includes it.
By their numbers in this assay, from the lowest: compounds 3, 2 and 1 (each within the scatter of the next).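

Working notes, continued: in this assay, the series now holds three groups on the aromatic nitrogen of the five-membered aromatic ring, and a 1.2-fold lower number from compound 2 to compound 3 (0.09 log units; within the scatter), so the larger 3,4,5-trihydroxy-6-(hydroxymethyl)oxan-2-yl cannot be separated from the group of compound 2. The comparison with the 3,4,5-trihydroxy-6-methyloxan-2-yl of compound 1 reads the same way, with a 1.4-fold lower number from compound 1 to compound 3 (0.13 log units; within the scatter), so the hydroxymethyl group in place of the methyl group brings no readable change in this assay, and all three compounds remain within the scatter of one another at this position. Nothing measured here offers an explanation for this flat reading.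

The compounds shown leave open whether the flat reading holds once the oxygen-containing six-membered ring is gone from this nitrogen, for example with a plain butyl chain or an aminoethyl chain in its place. They also leave open whether a carboxylic acid or an amine in place of the hydroxymethyl group of compound 3 would give a step beyond the scatter in this assay.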